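Adding a methoxy to compound 3

The compounds below may be only part of what the source reports. "The series", "measured", "known", "first", "only" and "open" are said of these compounds alone.

Measured in a functional assay on HeLa cells (Homo sapiens) for antiproliferative activity, read by MTT assay, with a stated time of 48 h; a higher number here means a weaker inhibitor, a lower number a stronger inhibitor
compound 1 `COc1ccc2c(/C=C/C(=O)c3cc(OC)c(OC)c([N+](=O)[O-])c3)c[nH]c2c1` gives 850 nM
compound 2 `COc1ccc2c(/C=C/C(=O)c3cc(OC)c(OC)c(SC)c3)cn(C)c2c1` gives 167 nM
compound 3 `COc1cc(C(=O)/C=C/c2cn(C)c3ccccc23)cc([N+](=O)[O-])c1OC` gives 1960 nM

Compound 3 stands at the weak end of this small set. Its number is the highest of the three, and its gaps to compound 1 and compound 2 both lie beyond the usual scatter of repeated measurements. Compound 1 is the nearer of the two and compound 2 the further.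

The next compound is compound 4 `COc1ccc2c(/C=C/C(=O)c3cc(OC)c(OC)c([N+](=O)[O-])c3)cn(C)c2c1` and the change from compound 3 is small. It is methoxy in place of hydrogen on an aromatic carbon and in words it is methoxy in place of hydrogen on an aromatic carbon.

Among the compounds with values here, no measured pair differs by this change alone, so its size in this assay cannot be read directly. There is only a weak hint. Compound 1 (850 nM) and compound 2 (167 nM) both carry this methoxy, and both give lower numbers than compound 3 (1960 nM) even though they differ from compound 4 elsewhere. A move toward stronger inhibition is therefore expected, with a step estimated as a 3.9-fold lower number from compound 3 to compound 4 (0.59 log units; beyond the scatter) and likely to exceed the scatter. For compound 4 the expected value is 500 nM within an estimated range from 150 nM to 1400 nM for now.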

Compound 4, half-maximal inhibitory concentration: 951 nM
Compound 4: middle estimate off by 1.9-fold (0.28 log units), on the low side, and the stated range covers the measured number.
By their numbers in this assay, from the lowest: compound 2; then compounds 1 and 4 (each within the scatter of the next); then compound 3.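

In this assay the methoxy on the aromatic carbon, meta to a fused ring and para to a fused ring, can now be read directly: it gives a 2.1-fold lower number from compound 3 to compound 4 (0.31 log units; beyond the scatter) as a modest step, and this step is beyond the scatter. With that methoxy in place, the two other single changes behave differently: methyl in place of hydrogen on the aromatic nitrogen gives a 1.1-fold higher number from compound 1 to compound 4 (0.05 log units; within the scatter) and stays within the scatter, so no effect can be claimed for it, whereas nitro in place of methylsulfanyl on an aromatic carbon gives a 5.7-fold higher number from compound 2 to compound 4 (0.76 log units; beyond the scatter) as a modest step beyond the scatter. No measurement at hand explains any of these steps.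

Among the compounds shown, this ring position carries only hydrogen or methoxy, so how a hydroxyl, a chlorine or the longer ethoxy would compare there remains open. On these data alone, the methoxy step has also been read only once, in compounds with nitro and a methyl on the nitrogen, so its size alongside methylsulfanyl or the hydrogen on the nitrogen is unknown.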